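The source may report more compounds than this note shows. Statements on the series, on what has been measured and on what is new or still open speak of the compounds shown alone.

Measured compounds:
compound 1 `C/C(=N/NC(=O)c1ccc(S(N)(=O)=O)cc1)c1ccccc1` gives 31100 nM
compound 2 `C/C(=N/NC(=O)c1ccc(S(N)(=O)=O)cc1)c1ccc(Br)cc1` gives 37600 nM
compound 3 `NS(=O)(=O)c1ccc(N/N=C(/CS(=O)(=O)c2ccccc2)c2ccccc2)cc1` gives 46100 nM

In an ADME assay on MCF-10A cells (Homo sapiens) for antiproliferative activity, read by MTT assay (on this read-out higher numbers stand for weaker inhibition and lower numbers for stronger inhibition), compound 1 gives 31100 nM, while compound 2 gives 37600 nM. The change between them is bromo in place of hydrogen on an aromatic carbon, and it made a 1.2-fold higher number from compound 1 to compound 2 (0.08 log units; within the scatter). Compound 3 is built on a different core; how that core differs from the core of compound 1 is not broken down here. In this assay compound 3 gives 46100 nM, which sits within the scatter of the other two.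

Compound 4 `NS(=O)(=O)c1ccc(N/N=C(/CS(=O)(=O)c2ccccc2)c2ccc(Br)cc2)cc1` has not yet been measured in this assay. It differs from compound 3 by bromo in place of hydrogen on an aromatic carbon, the same change as from compound 1 to compound 2. Because that earlier change gave a 1.2-fold higher number from compound 1 to compound 2 (0.08 log units; within the scatter), a step of a 1.1-fold higher number from compound 3 to compound 4 (0.05 log units; within the scatter) is expected here, again within the scatter. Compound 4 is therefore estimated at 52000 nM, between 26000 nM and 104000 nM.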

Compound 4, half-maximal inhibitory concentration: 12900 nM
The estimate for compound 4 lay 4.0-fold (0.61 log units) above the measured number; the whole stated range lies above it.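

In this assay, bromo in place of hydrogen on an aromatic carbon gave a 3.6-fold lower number from compound 3 to compound 4 (0.55 log units; beyond the scatter), so the change did not carry over with the same size from one core to the other: the same change on two cores in this assay, a 1.2-fold higher number (0.08 log units; within the scatter) from compound 1 to compound 2 and a 3.6-fold lower number (0.55 log units; beyond the scatter) from compound 3 to compound 4, 4.3-fold (0.64 log units) apart, beyond the scatter of two such steps. Within the data shown here, on the core of compound 1 the step stayed within the scatter, while on the core of compound 3 it went beyond it, so the step on one core was no guide to the step on the other. This rests on a single pair per core and does not show which part of the two cores accounts for the gap. The compounds shown leave open whether chloro, methoxy or an amine in the same place would follow the phenyl to 4-bromophenyl step on the core of compound 3.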